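Moving the Halogen Around the Ring Before Measurement

The source may report more compounds than this note shows. Statements on the series, on what has been measured and on what is new or still open speak of the compounds shown alone.

Compound 2 `Nc1ccccc1NC(=O)CCCNCC(=O)Nc1ccc(Br)cc1` gives 68.7% in a functional assay on the whole organism (Ehrlich cells, Mus musculus) for antiproliferative activity, with a stated time of 24 h, at a dose of 0.2 mmol/kg by the intraperitoneal route (on this read-out higher numbers stand for more inhibition at the one dose given (going by the name of the read-out) and lower numbers for less inhibition), the highest of the three measured numbers. Compound 3 `Nc1ccccc1NC(=O)c1ccc(NCC(=O)Nc2cccc([N+](=O)[O-])c2)cc1` gives 40.4% in this assay and compound 1 `Nc1ccccc1NC(=O)CCCNCC(=O)Nc1cccc(Cl)c1` gives 22.5%, both standing below compound 2 beyond the scatter. Among the compounds with values here, the only measured single-site step is a number 46.2 percentage points higher from compound 1 to compound 2 (beyond the scatter), which shows that the halogen and its place on this ring can shift inhibition considerably. Compound 4 `Nc1ccccc1NC(=O)CCCNCC(=O)Nc1ccccc1Cl` differs from compound 2 by 2-chlorophenyl in place of 4-bromophenyl on an amide-type nitrogen. Within the data shown here, no measured pair isolates this change, so the expectation rests on the size of that one step alone. The step of a number 28.7 percentage points lower from compound 2 to compound 4 (beyond the scatter) is therefore expected to run downward. Compound 4 is estimated at 40%, with a range from 15% to 68%.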

Compound 4, a percentage reported as inhibition, in the whole organism at one dose (the size of the read-out at that dose, not a potency): 12.7%
The estimate for compound 4 lay 27.3 percentage points above the measured number, and the stated range ends above it.
By their numbers in this assay, from the lowest: compounds 4 and 1 (each within the scatter of the next); then compound 3; then compound 2.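

On this amide-type nitrogen, 2-chlorophenyl in place of 4-bromophenyl gives a number 56 percentage points lower from compound 2 to compound 4 (beyond the scatter) and so confirms a large drop for a second chlorophenyl compound. The step of a number 9.8 percentage points lower from compound 1 to compound 4 (within the scatter) shows that 2-chlorophenyl and 3-chlorophenyl cannot be told apart here, so the place of the chlorine on this ring makes no difference beyond the scatter. Nothing available bears on why these changes act as they do. From the compounds shown here alone, what 4-chlorophenyl would give at this nitrogen remains open, and with it whether the bromine or its place on the ring sets compound 2 apart.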